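From isopropyl to benzyl on a shared core

This account rests on a few compounds, and the source may have more. Where it says the series, first, only, none or still open, it means among the compounds named here.

Values so far in a functional assay (muscle tissue) with Felis catus as the target (on this read-out lower numbers stand for an effect already at smaller amounts and higher numbers for an effect only at larger amounts of compound), for the measured compounds
- compound 1 `Cc1nc(O)c(C#N)c(NCc2ccco2)n1` gives 10000 nM
- compound 2 `CCNc1nc(C)nc(O)c1C#N` gives 2600 nM
- compound 3 `CC(C)c1nc(O)c(C#N)c(NCc2cccnc2)n1` gives 33000 nM

Compound 3 stands highest of the three in this assay and its gaps to both other compounds lie beyond the scatter, with compound 1 the nearer of the two. Compound 4 `N#Cc1c(O)nc(Cc2ccccc2)nc1NCc1cccnc1` carries benzyl in place of isopropyl on an aromatic carbon and is otherwise the same as compound 3.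

Among the compounds with values here, only one measured step links compounds that differ in a single place. This is a 3.8-fold lower number from compound 1 to compound 2 (0.59 log units; beyond the scatter) and it is modest, with methyl in place of furan-2-yl on a saturated chain carbon bound to a nitrogen on an aromatic ring. Within the data shown here, that exchange lies elsewhere on the molecule, so the data hold no direct precedent for the present change, and the step offers only a rough guide to size. A small shift is expected, leaning towards a lower number because compound 3 at 33000 nM is the highest of the three values. The expected change is a 1.7-fold lower number from compound 3 to compound 4 (0.22 log units; within the scatter) and it may well stay within the scatter. For compound 4 the estimated value is 20000 nM with an expected range from 6000 nM to 60000 nM in this wide estimate.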

Compound 4, half-maximal effective concentration: 72000 nM
The estimate for compound 4 lay 3.6-fold (0.56 log units) below the measured number; the whole stated range lies below it.
By their numbers in this assay, from the lowest: compound 2; then compound 1; then compound 3; then compound 4.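

In this assay, benzyl in place of isopropyl on the aromatic carbon between two ring nitrogen atoms gives a 2.2-fold higher number from compound 3 to compound 4 (0.34 log units; beyond the scatter), a modest step but one beyond the scatter. Within the data shown here, this is the first evidence that this position, and not only the substituent on the ring-bound nitrogen, can shift the number, and here the shift is upward. Replacing a group of 3 heavy atoms with no ring by one of 7 heavy atoms carrying a six-membered aromatic ring did not move the effect towards smaller amounts of compound, although the data offer no measured property that bears on this rise.

With only these two groups compared at this position on a shared nitrogen substituent, the added ring cannot be separated from the added carbon count, and a cyclohexylmethyl group or a straight butyl chain would be needed to tell those two apart. From the compounds shown here alone, it also remains open whether the same exchange would change the number similarly with furan-2-ylmethyl on the nitrogen, or how a directly attached phenyl or an amine would behave at this position.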